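Amide substituent variation at the carbonyl carbon

A few compounds are considered here, and "the series" means these few. Any claim that something is new, unique, unknown or untested is made for them only; others in the source may bear on it.

Working notes on the series. Among the compounds with values here, compound 2 `COc1ccc(COC(=O)[C@H](CSCC2CCCCC2)NC(=O)CC(C)C)cc1` stands highest of the two numbers measured so far in an assay on IMR-32 cells for inhibition of Voltage-dependent N-type calcium channel subunit alpha-1B (Homo sapiens) (on this read-out higher numbers stand for weaker inhibition and lower numbers for stronger inhibition), where compound 2 gives 1200 nM. Its nearest neighbour is compound 1 `COc1ccc(COC(=O)[C@H](CSCC2CCCCC2)NC(=O)OC(C)(C)C)cc1`, which in this assay gives 610 nM; the step of a 2.0-fold higher number from compound 1 to compound 2 (0.29 log units; within the scatter) lies within the scatter, so the two values show no real separation.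

Compound 3 `COc1ccc(COC(=O)[C@H](CSCC2CCCCC2)NC(=O)[C@@H]2CCCN2C(=O)OC(C)(C)C)cc1` is not yet measured. The change is 1-(tert-butoxycarbonyl)pyrrolidin-2-yl in place of isobutyl on a carbonyl carbon whose other neighbour is the amide-type nitrogen. Within the data shown here, only one measured step touches the same carbonyl carbon: a 2.0-fold higher number from compound 1 to compound 2 (0.29 log units; within the scatter) exchanged tert-butoxy for isobutyl and stayed within the scatter. Among the measured compounds shown here, no measured pair covers the entry of a five-membered ring with a tert-butoxycarbonyl group at this position, so the guidance is thin; on that basis the expected step is a 1.2-fold lower number from compound 2 to compound 3 (0.08 log units; within the scatter), nothing beyond the scatter in either direction. For compound 3 the estimate in this assay is 1000 nM, with a range from 350 nM to 3500 nM.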

Compound 3, half-maximal inhibitory concentration: 880 nM
Beside the measured number, compound 3's estimate is 1.1-fold (0.06 log units) above it; low and high end bracket the measured number.
By their numbers in this assay, from the lowest: compounds 1, 3 and 2 (each within the scatter of the next).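

Against the earlier pair, compound 3 puts a far bulkier substituent on the carbonyl carbon whose other neighbour is the amide-type nitrogen: 1-(tert-butoxycarbonyl)pyrrolidin-2-yl has 12 heavy atoms, one five-membered non-aromatic ring and a defined stereocentre, where isobutyl has 4 heavy atoms and no ring. In this assay, this change gives a 1.4-fold lower number from compound 2 to compound 3 (0.13 log units; within the scatter), and the exchange for tert-butoxy gives a 1.4-fold higher number from compound 1 to compound 3 (0.16 log units; within the scatter), so the three substituents show no real separation and the number at this position has so far not responded to the entry of a ring or to this increase in heavy atoms. The data shown offer no explanation for this outcome.

On these data alone, it remains open whether any group on this carbonyl carbon can move the number beyond the scatter, for example a pyrrolidin-2-yl with a free ring nitrogen, a primary amine or a carboxylic acid on a longer chain. The role of the defined stereocentre also remains open, as the opposite configuration at the pyrrolidine carbon does not appear among these compounds.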